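The source may report more compounds than this note shows. Statements on the series, on what has been measured and on what is new or still open speak of the compounds shown alone.

Compound 1 `CCn1cc(COc2cc(O)c3c(c2)O[C@H](c2ccc(OC)c(O)c2)C/C3=N\O)nn1` gives the lowest number among the three measured compounds in a functional assay on RAW264.7 cells (Mus musculus) for inhibition, read by Griess assay, with stated times of 2 h and 24 h (a lower number here means a stronger inhibitor, a higher number a weaker inhibitor), with 3140 nM. Compound 2 `C#CCOc1cc(O)c2c(c1)O[C@H](c1ccc(OC)c(O)c1)C/C2=N\O` gives 19100 nM, and the step of a 6.1-fold higher number from compound 1 to compound 2 (0.78 log units; beyond the scatter) shows that removing the triazole ring weakens inhibition. Compound 3 `COc1ccc([C@@H]2CC(=O)c3c(O)cc(OCc4cn(Cc5ccccc5)nn4)cc3O2)cc1O` gives 11000 nM; it differs from compound 1 in two places at once, so its higher number cannot be tied to either change alone. Compound 4 `COc1ccc([C@@H]2C/C(=N\O)c3c(O)cc(OCc4cn(Cc5ccccc5F)nn4)cc3O2)cc1O` keeps the oxime of compound 1 and changes only the group on the triazole: 2-fluorophenyl in place of methyl on a saturated chain carbon bound to an aromatic nitrogen. Within the data shown here, no measured step isolates this change. Compound 4 is therefore expected to give a number near that of compound 1, perhaps somewhat higher, an expected step of a 1.6-fold higher number from compound 1 to compound 4 (0.20 log units; within the scatter). The estimated value for compound 4 in this assay is 5000 nM, within a range of 1800 nM to 15000 nM.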

Compound 4, half-maximal inhibitory concentration: 5710 nM
Compound 4: the middle estimate sits 1.1-fold (0.06 log units) below what was measured; the range from low to high includes it.
By their numbers in this assay, from the lowest: compounds 1, 4, 3 and 2 (each within the scatter of the next, the first and the last beyond it).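

In this assay, the change from ethyl to 2-fluorobenzyl gives a 1.8-fold higher number from compound 1 to compound 4 (0.26 log units; within the scatter) and so stays within the scatter: at this position on the triazole, a group carrying an aromatic ring performs no differently from the small ethyl group. Among these compounds, none of the earlier steps tested this position. No measurement shown here explains this result.

Going by these compounds, it remains open whether the fluorine contributes anything to the number. On these data alone, it is also open how a longer alkyl chain, an amine or a carboxylic acid at this position would behave.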